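This account rests on a few compounds, and the source may have more. Where it says the series, first, only, none or still open, it means among the compounds named here.

Measured compounds:
compound 1 `CC[C@@H]1C(=O)N(C)c2cnc(-n3ccc4cc(F)ccc43)nc2N1C1CCCC1`: "not active" (no number reported)
compound 2 `CC[C@@H]1C(=O)N(C)c2cnc(Nc3ccc(S(=O)(=O)NCCO)cc3)nc2N1C1CCCC1`: 459 nM
compound 3 `CCC1C(=O)N(C)c2cnc(Nc3ccc(S(=O)(=O)NCCCO)cc3)nc2N1c1ccn(C)n1`: 23700 nM

In a functional assay on HeLa cells (Homo sapiens) for antiproliferative activity, read by CCK-8 assay, with a stated time of 72 h (on this read-out higher numbers stand for weaker inhibition of growth and lower numbers for stronger inhibition of growth), compound 1 is reported as not active, with no number behind it. Among the measured compounds shown here, compound 2 gives 459 nM and compound 3 gives 23700 nM; no step between any pair is computed, so these two values stand only as read. Compound 1 therefore holds no place on the numbers shown; its standing is the bare statement of inactivity.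

Compound 4 `CC[C@@H]1C(=O)N(C)c2cnc(-n3ccc4cc(C(=O)NC5CCCC5)ccc43)nc2N1C1CCCC1` is not yet measured. It differs from compound 1 by cyclopentylcarbamoyl in place of fluoro on an aromatic carbon, the cyclopentylcarbamoyl sitting meta to a fused ring and para to a fused ring on the six-membered aromatic ring of the two-ring system. For the measured compounds named here, no measured pair mirrors this exchange, so no size of step in this assay can be drawn from the data; a shift toward stronger inhibition is possible but unsupported. For compound 4, growth inhibition is estimated at 5000 nM with an expected range of 800 nM to 30000 nM.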

Compound 4, concentration for 50% growth inhibition: 247 nM
Estimate against measurement, compound 4: 20-fold (1.31 log units) above, and the stated range ends above it.
By their numbers in this assay, from the lowest: compounds 4 and 2 (each within the scatter of the next); then compound 3.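

Among the compounds shown here, compound 1 carries no number in this assay, so no step to compound 4 can be read. The compounds shown leave open how large the exchange of fluoro for cyclopentylcarbamoyl is. No measurement shown bears on a cause.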